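Swapping the pyridyl attachment point on a shared core

The compounds below may be only part of what the source reports. "The series", "measured", "known", "first", "only" and "open" are said of these compounds alone.

Of the compounds shown here, three built on one shared core have been measured in an assay on isolated protein for inhibition of DNA topoisomerase 1 (Homo sapiens), with a stated time of 30 min, tested at 100 uM; a lower number here means a weaker effect, a higher number a stronger effect of the compound at the concentration tested. Compound 1 `Oc1ccc(-c2cc(-c3cccnc3)nc(-c3ccccc3Cl)c2)cc1` gives 0.9%, compound 2 `Oc1ccc(-c2cc(-c3cccc(Cl)c3)nc(-c3ccccn3)c2)cc1` gives 59.4%, and compound 3 `Oc1ccc(-c2cc(-c3ccncc3)nc(-c3ccc(Cl)cc3)c2)cc1` gives 5.9%. Compound 3 stands second highest of the three numbers; its nearest neighbour is compound 1, a number only slightly lower and within the scatter, while compound 2 sits far above it, a gap well beyond the scatter.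

Compound 4 `Oc1ccc(-c2cc(-c3ccc(Cl)cc3)nc(-c3ccccn3)c2)cc1` has not yet been measured. It has the same atoms as compound 3, joined differently: pyridin-2-yl in place of pyridin-4-yl on an aromatic carbon. The group sits next to the ring nitrogen of the core, meta to a 4-chlorophenyl group and meta to a 4-hydroxyphenyl group.

Among the compounds with values here, no single-change step between measured compounds is available. Within the data shown here, compound 2 is the only measured compound carrying pyridin-2-yl, and compound 2 gives the highest number, though it differs from compound 4 in a second place as well. On that basis an upward step in this assay is expected, likely beyond the scatter, though its size is uncertain. The expected step is a number 29.1 percentage points higher from compound 3 to compound 4 (beyond the scatter). Compound 4 is estimated at 35%, within a range from 5% to 65%.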

Compound 4, a percentage reported as inhibition, at one concentration (the size of the read-out at that concentration, not a potency): 12.7%
The estimate for compound 4 lay 22.3 percentage points above the measured number, and the stated range covers the measured number.
By their numbers in this assay, from the lowest: compounds 1, 3 and 4 (each within the scatter of the next, the first and the last beyond it); then compound 2.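

In this assay, pyridin-2-yl in place of pyridin-4-yl, with the 4-chlorophenyl and 4-hydroxyphenyl groups kept on the shared core, gives a number 6.8 percentage points higher from compound 3 to compound 4 (within the scatter) and so does not clearly change the reading. The second comparison keeps pyridin-2-yl fixed: 4-chlorophenyl in place of 3-chlorophenyl gives a number 46.7 percentage points lower from compound 2 to compound 4 (beyond the scatter) and shows that pyridin-2-yl alone does not bring a high number, since the chlorophenyl change is the one with a large step among these compounds. Nothing measured here explains why one change has so much more effect than the other.

The compounds shown leave open whether the 3-chlorophenyl group would keep its high reading with pyridin-4-yl or pyridin-3-yl in place of pyridin-2-yl, a pairing that would show whether the two groups depend on each other. They also leave open whether the chlorine itself is needed, which a 3-methoxyphenyl or 3-aminophenyl group in place of the 3-chlorophenyl group would begin to test.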